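Carbamate Exchange on a Pair with Low Numbers

The source may hold more compounds than are shown below. What is called first, only, known or untested is meant among the compounds shown, and "the series" means these compounds.

Compound 1 `CC(C)=CCC/C(C)=C/CC1Cc2c(OCCCNC(=O)c3ccco3)cc(=O)n(CCCO)c2CC1(C)C` and compound 2 `COc1ccccc1NC(=O)Oc1cc(=O)n(CCCO)c2c1CC(C/C=C(\C)CCC=C(C)C)C(C)(C)C2` were examined in a functional assay on PANC-1 cells (Homo sapiens) for inhibition, read by MTT assay, with a stated time of 24 h, tested at 10 uM; a higher number here means more inhibition at the concentration tested (going by the name of the read-out), a lower number less inhibition. Compound 1 gives 2.8%, and compound 2 gives 0%. Going by the values given here, compound 2 therefore stands lowest of the two numbers, with its nearest neighbour compound 1 within the scatter, as the single measured step of a number 2.8 percentage points lower from compound 1 to compound 2 (within the scatter) shows.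

Compound 3 `CC(C)=CCC/C(C)=C/CC1Cc2c(OC(=O)Nc3ccc(F)cc3)cc(=O)n(CCCO)c2CC1(C)C` differs from compound 2 by 4-fluorophenyl in place of 2-methoxyphenyl on an amide-type nitrogen. Among the compounds with values here, no measured step changes the aryl group on the amide-type nitrogen, so the only guidance is that both measured compounds sit near the floor of this assay and that the one step seen stayed within the scatter. Compound 3 is therefore expected to move by a number 3 percentage points higher from compound 2 to compound 3 (within the scatter), that is, no step beyond the scatter. Compound 3 is estimated at 3%, with a range from -8% to 15%.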

Compound 3, a percentage reported as inhibition, at one concentration (the size of the read-out at that concentration, not a potency): 6.2%
Beside the measured number, compound 3's estimate is 3.2 percentage points below it; the range from low to high includes it.
By their numbers in this assay, from the lowest: compounds 2, 1 and 3 (each within the scatter of the next).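

In this assay, going by these compounds alone, the aryl group on the amide-type nitrogen changes for the first time, and 4-fluorophenyl in place of 2-methoxyphenyl gives a number 6.2 percentage points higher from compound 2 to compound 3 (within the scatter) at this place. Exchanging 3-(((furan-2-yl)carbonyl)amino)propyl for (4-fluorophenyl)carbamoyl on an oxygen on an aromatic ring gives a number 3.4 percentage points higher from compound 1 to compound 3 (within the scatter), so this second carbamoyl group, like the first, does not separate from compound 1 in this assay. Nothing available offers an explanation for these small differences.

The compounds shown leave open whether any group on the amide-type nitrogen can lift the number clear of the scatter, such as a phenyl ring carrying a carboxylic acid or an amine. They also leave open what a simple alkyl chain would do there.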